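A few compounds are considered here, and "the series" means these few. Any claim that something is new, unique, unknown or untested is made for them only; others in the source may bear on it.

Measured so far:
compound 1 `CN1C[C@H]2C=C(c3cccnc3)C[C@H](C2)C1` — 19%
compound 2 `Clc1ccc(C2=CC3CNCC(C2)C3)cn1` — 98%

In an in vitro functional assay on SH-EP1 cells for agonist activity at Neuronal acetylcholine receptor; alpha4/beta2 (Homo sapiens), read by FLIPR and calcium flux (on this read-out higher numbers stand for larger maximal responses and lower numbers for smaller maximal responses), compound 1 gives 19%, the lower of the two numbers recorded. Among the compounds with values here, compound 2, the only other measured compound, gives 98% in this assay, a figure well beyond the scatter above compound 1; the two compounds differ in more than one place, so their gap cannot be tied to a single change. Compound 3 `C1=C(c2cccnc2)C[C@H]2CNC[C@@H]1C2` has not yet been measured. It differs from compound 1 in one place: hydrogen in place of methyl on an amine nitrogen in a ring. Within the data shown here, no single-change step between measured compounds exists to calibrate this. Compound 2 also carries hydrogen on that amine nitrogen in a ring and sits high, so the step from compound 1 to compound 3 is expected to be upward and large, about a number 56 percentage points higher from compound 1 to compound 3 (beyond the scatter). Compound 3 is therefore estimated at 75%, within a range of 40% to 100%.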

Compound 3, largest response reached (reported as percent of maximum), in percent of the reference or control that the assay uses: 114%
For compound 3 the middle estimate is 39 percentage points below the measured one, outside the stated range (above it).
By their numbers in this assay, from the lowest: compound 1; then compound 2; then compound 3.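

Hydrogen in place of methyl on an amine nitrogen in a ring gives a number 95 percentage points higher from compound 1 to compound 3 (beyond the scatter) in this assay as the first single-change step among these compounds. It shows that this one position, on an amine nitrogen in a ring of a six-membered non-aromatic ring with 1 nitrogen, strongly governs the maximal response: with the rest of the core of compound 1 unchanged, losing the methyl alone carries the read-out from the bottom to the top of the recorded numbers. Nothing measured here explains the size of this step.

On these data alone, it remains open whether ethyl, a longer chain or an acetyl group on that nitrogen would leave the response nearer compound 1 or nearer compound 3. As far as these compounds go, it is also open whether methyl on the same nitrogen of compound 2 would lower its response to a similar extent.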